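Resolving the stereocentre of compound 1

This account rests on a few compounds, and the source may have more. Where it says the series, first, only, none or still open, it means among the compounds named here.

Compound 1 `CC1=C(C(=O)OCCO[N+](=O)[O-])C(c2cccc3nonc23)C([N+](=O)[O-])=C(C)C1` is characterised in a functional assay (cardiac atrium) for agonist activity, with Cavia porcellus as the target (a lower number here means that less compound is needed, a higher number that more compound is needed for the effect), where compound 1 gives 31100 nM. Among the compounds with values here, compound 2 `CC1=C(C(=O)OC(C)C)C(c2cccc3nonc23)C([N+](=O)[O-])=C(C)C1` is the only other measured member of the set; in this assay compound 2 gives 9400 nM. Within the data shown here, the single measured step, a 3.3-fold lower number from compound 1 to compound 2 (0.52 log units; beyond the scatter), leaves compound 1 with the highest of the two numbers and compound 2 as its nearest neighbour.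

Compound 3 `CC1=C(C(=O)OCCO[N+](=O)[O-])[C@H](c2cccc3nonc23)C([N+](=O)[O-])=C(C)C1` differs from compound 1 as follows: the two compounds have the same atoms and bonds; at least one stereo element is drawn with a configuration in one of them and without one in the other: 1 of 1 stereo elements differ; a stereocentre at a saturated ring carbon is drawn without a configuration in compound 1 and S in compound 3. Nothing else changes. Among the measured compounds shown here, the step from compound 1 to compound 2 concerns the group on the ester oxygen, not the stereocentre, so no measured step in the set bears on the present change. For the measured compounds named here, a single drawn configuration taken from a compound drawn without one can give a lower number, if the drawn enantiomer carries the activity, or a higher one, if it does not; with no resolved pair among the measured compounds the direction remains open. The estimate for compound 3 is anchored on the value of compound 1 because compound 1 gives 31100 nM with the centre kept close and the range wide. Compound 3 is expected to give 28000 nM in this assay, within 9000 nM to 90000 nM, an expected step of a 1.1-fold lower number from compound 1 to compound 3 (0.05 log units; within the scatter).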

Compound 3, half-maximal effective concentration: 3130 nM
Compound 3: the middle estimate sits 8.9-fold (0.95 log units) above what was measured; the whole stated range lies above it.
By their numbers in this assay, from the lowest: compound 3; then compound 2; then compound 1.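

In this assay, fixing the saturated ring carbon as S gives a 9.9-fold lower number from compound 1 to compound 3 (1.00 log units; beyond the scatter). Within the data shown here, this is the first measured step at the stereocentre, and it settles the direction that the ester step a 3.3-fold lower number from compound 1 to compound 2 (0.52 log units; beyond the scatter) could not address: for this pair, the compound drawn with the S configuration needs less compound for the effect than the one drawn without a configuration. With no atom or bond changed and no other difference between the two structures, the step is attributed to a single feature because that is all that separates them: the fact that one of compounds 1 and 3 is drawn with a defined configuration and the other without, at the place where they differ

Still open, as far as these compounds go, is the number for the R configuration at this carbon, which would show directly how far the two configurations differ in this assay and whether the value of compound 1 can be read as a blend of the two. Also open, from the compounds shown here alone, is whether the S configuration gives a step of similar size and direction with the isopropyl group of compound 2 on the ester oxygen, or with a longer chain ending in an amine at that oxygen.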